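This account rests on a few compounds, and the source may have more. Where it says the series, first, only, none or still open, it means among the compounds named here.

Compound 1 `C/C=C1/[C@H](O[C@@H]2O[C@H](CO)[C@@H](O)[C@H](O)[C@H]2O)OC=C(C(=O)OC)[C@H]1CC(=O)NCCC`: in a functional assay on SK-BR-3 cells (Homo sapiens) for antiproliferative activity, read by MTT assay, with a stated time of 72 h (on this read-out higher numbers stand for weaker inhibition and lower numbers for stronger inhibition), compound 1 gives > 20000 nM, which is a limit of the assay and not a number.
Compound 2 `C/C=C1/[C@H](O[C@@H]2O[C@H](CO)[C@@H](O)[C@H](O)[C@H]2O)OC=C(C(=O)OC)[C@H]1CC(=O)OCCCc1ccc(OC)c(OC)c1`: in this assay compound 2 gives > 20000 nM, again a limit rather than a number.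
Compound 3 `C/C=C1/[C@H](O[C@@H]2O[C@H](CO)[C@@H](O)[C@H](O)[C@H]2O)OC=C(C(=O)OC)[C@H]1CC(=O)OCCc1ccc(OC)cc1`: in this assay compound 3 gives > 20000 nM, also a limit.

Compound 3 therefore stands where every measured compound stands, at the limit of > 20000 nM in this assay, at which 3 of the 3 values shown sit; no number separates it from compound 1 or compound 2. Compound 4 `C/C=C1/[C@H](O[C@@H]2O[C@H](CO)[C@@H](O)[C@H](O)[C@H]2O)OC=C(C(=O)OC)[C@H]1CC(=O)OCCc1ccc(O)c(O)c1` differs from compound 3 as follows: 3,4-dihydroxyphenyl in place of 4-methoxyphenyl on a saturated chain carbon, two bonds along the chain from an oxygen next to a carbonyl group. For the measured compounds named here, two measured steps touch the same place or the same carbonyl, a step that the two limits leave unreadable from compound 1 to compound 3 and a step that the two limits leave unreadable from compound 2 to compound 3, but their size cannot be read because the limit of > 20000 nM in this assay, at which 3 of the 3 values shown sit, hides both ends of each. With no readable step to go on, the change is expected to leave the read-out where it is, so the step from compound 3 to compound 4 is expected to be a step that the limit leaves unreadable from compound 3 to compound 4. Compound 4 is therefore estimated at 30000 nM, within 8000 nM to 120000 nM, and most likely reported once more as a limit.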

Compound 4, half-maximal inhibitory concentration: 160000 nM
Estimate against measurement, compound 4: 5.3-fold (0.73 log units) below; measured number outside the range, above it.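

No step from compound 1, compound 2 or compound 3 to compound 4 can be read, because each of those three compounds gives only a limit and not a number: the limit of > 20000 nM in this assay, at which 3 of the 4 values shown sit.

From the compounds shown here alone, whether compound 4 truly differs from any of them in this assay, and by how much, stays open.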